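The source may hold more compounds than are shown below. What is called first, only, known or untested is meant among the compounds shown, and "the series" means these compounds.

Of the compounds shown here, three built on one shared core have been tested in an assay on HL-60 cells for inhibition of glutathione S-transferase P (Homo sapiens), read by spectrophotometry, tested at 20 uM; on this read-out higher numbers stand for more inhibition at the one concentration tested (going by the name of the read-out) and lower numbers for less inhibition. Compound 1 `COc1cc(/C=C2\CN(CC(=O)O)c3c(C)cccc3C2=O)cc(OC)c1` gives 32.3% in this assay. Compound 2 `COc1cccc(/C=C2\CN(CC(=O)O)c3ccc(C)cc3C2=O)c1` gives 14.4% in this assay, and compound 3 `COc1ccc(/C=C2\CN(CC(=O)O)c3c(Cl)cccc3C2=O)c(OC)c1OC` gives 23.6% in this assay. The number for compound 3 falls between those of compound 1 and compound 2, yet each of those two lies within the usual scatter of it, so no ranking of the three can be drawn from these numbers. Compound 4 `COc1ccc(/C=C2\CN(CC(=O)O)c3c(C)cccc3C2=O)c(OC)c1OC` differs from compound 3 in one place: methyl in place of chloro on an aromatic carbon. Among the measured compounds shown here, no single step between measured compounds is available, and compound 1 carries a methyl on its core but a different aryl part, so it offers no direct comparison. The chemist therefore expects in this assay a step of a number 4.4 percentage points higher from compound 3 to compound 4 (within the scatter), nothing beyond the scatter. Compound 4 is estimated at 28%, with a range from 15% to 41%.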

Compound 4, a percentage reported as inhibition, at one concentration (the size of the read-out at that concentration, not a potency): 1.57%
Compound 4: the middle estimate sits 26.4 percentage points above what was measured; the measured number lies below the stated range.
By their numbers in this assay, from the lowest: compound 4; then compounds 2, 3 and 1 (each within the scatter of the next, the first and the last beyond it).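

In this assay, among the compounds shown here, putting methyl in place of chloro on this aromatic carbon gives a number 22 percentage points lower from compound 3 to compound 4 (beyond the scatter) and is the first single change on the shared core whose effect can be read. With the aryl part held constant, the group at this carbon matters, and chloro gives the higher number of the two. Nothing measured here bears on why this step occurs.

As far as these compounds go, whether fluoro, bromo, methoxy or an amine at this carbon would come closer to chloro or to methyl remains open. So does whether the step would hold with a different aryl part, such as that of compound 1.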